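The source may report more compounds than this note shows. Statements on the series, on what has been measured and on what is new or still open speak of the compounds shown alone.

The study concerns two hydrazone compounds built on a shared core and read in a physicochemical assay, read by spectrophotometry, with a stated time of 15 min; on this read-out higher numbers stand for weaker inhibition and lower numbers for stronger inhibition. Compound 1, `COc1ccc(/C=N/NC(=O)CCCc2nc3ccccc3c(=O)[nH]2)cc1`, gives 280000000 nM in this assay, the higher of the two numbers recorded, so that it stands as the weaker of the pair. Compound 2, `O=C(CCc1nc2ccccc2c(=O)[nH]1)N/N=C/c1cc(O)c(O)c(O)c1`, gives 45000000 nM in this assay, a lower number that lies beyond the scatter of repeated measurements from the value of compound 1. Among the compounds with values here, no step between compounds differing in a single place has been worked out, so only these two values frame what follows.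

Compound 3, `COc1cc(/C=N/NC(=O)CCCc2nc3ccccc3c(=O)[nH]2)ccc1O`, has not yet been measured. It departs from compound 1 by one change, (4-hydroxy-3-methoxyphenyl in place of 4-methoxyphenyl on a carbon with a double bond to nitrogen). The core and the linking chain are otherwise kept.

The new compound carries one hydrogen-bond donor where compound 1 carries none, and compound 2, which gives the lower number, carries several. On that basis the step is expected to run downward, toward stronger inhibition, with a 2.5-fold lower number from compound 1 to compound 3 (0.41 log units; beyond the scatter) as the anticipated size, a step judged to lie beyond the scatter. Compound 3 is therefore estimated at 110000000 nM in this assay, within a range from 40000000 nM to 280000000 nM.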

Compound 3, half-maximal inhibitory concentration: 280000000 nM
Estimate against measurement, compound 3: 2.5-fold (0.41 log units) below; low and high end bracket the measured number.
By their numbers in this assay, from the lowest: compound 2; then compounds 1 and 3 (each within the scatter of the next).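

In this assay, within the data shown here, placing 4-hydroxy-3-methoxyphenyl in place of 4-methoxyphenyl on a carbon with a double bond to nitrogen gives no change at the digits printed from compound 1 to compound 3 (within the scatter), the first step between two compounds that differ in only one place. At this position, therefore, the entering group brings one hydrogen-bond donor and one further hydrogen-bond acceptor, yet the read-out does not separate compound 3 from compound 1. Nothing available bears on why these two compounds read alike.

The compounds shown leave open whether a group of another kind at this place, such as an amine, a carboxylic acid or a nitro group, would separate itself from compound 1 in this read-out, and whether 4-hydroxyphenyl, carrying the hydroxy group without the accompanying methoxy group, would read as compound 3 does. Among these compounds, they also leave open what a longer chain between the shared core and the hydrazone would do with either aromatic group in place, since no step that changes the chain alone is available.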